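The compounds below may be only part of what the source reports. "The series", "measured", "known", "first", "only" and "open" are said of these compounds alone.

Working notes, values from an assay for inhibition of protein disulfide-isomerase (Homo sapiens), with a stated time of 1 h; a higher number here means a weaker inhibitor, a lower number a stronger inhibitor.

Compound 1 `Cc1ccnc(NC(c2ccc(C(F)(F)F)cc2)c2ccc3cccnc3c2O)c1`: in this assay compound 1 gives 26500 nM.
Compound 2 `Oc1ccc2ncccc2c1C(c1ccc(F)cc1)N1CCCCC1`: compound 2 returns only a limit, > 30000 nM.
Compound 3 `CCc1ccc(C(Nc2ccccn2)c2ccc3cccnc3c2O)cc1`: compound 3 gives 170 nM.

Compound 1 stands at the higher of the two numbers in this assay, and its nearest neighbour, compound 3, sits far lower, well beyond the scatter of repeated measurements. Compound 2 adds no number, only (the limit of > 30000 nM in this assay, at which 1 of the 3 values shown sits).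

Compound 4 `Cc1ccnc(NC(c2ccc([N+](=O)[O-])cc2)c2ccc3cccnc3c2O)c1` has not yet been measured in this assay. It differs from compound 1 in one place: nitro in place of trifluoromethyl on an aromatic carbon. Among the measured compounds shown here, no pair of measured compounds in this set shows that exchange, and compound 2 and compound 3 differ from compound 1 in other places, so they give no guide to its size. The expectation is a step of about the size of the scatter, at most slightly beyond it, toward a lower number, from compound 1 to compound 4 a 1.5-fold lower number from compound 1 to compound 4 (0.17 log units; within the scatter). Compound 4 is therefore estimated at 18000 nM, with a range of 5000 nM to 60000 nM. Compound 1 gives 26500 nM, a high number in this assay. Compound 4 may therefore return only a limit rather than a number.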

Compound 4, half-maximal inhibitory concentration: 530 nM
Beside the measured number, compound 4's estimate is 34-fold (1.53 log units) above it; the measured number lies below the stated range.
By their numbers in this assay, from the lowest: compound 3; then compound 4; then compound 1. At a limit, above all of these: compound 2.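

In this assay, nitro in place of trifluoromethyl on an aromatic carbon, para to a large group, gives a 50-fold lower number from compound 1 to compound 4 (1.70 log units; beyond the scatter). Among the compounds shown here, the earlier compounds included no pair differing in one place, so this is the first direct evidence that this position alone can move the number by a large amount: with the rest of the structure unchanged, compound 1 gives 26500 nM and compound 4 gives 530 nM. No measured property in the notes bears on why the exchange has this effect.

A single exchange at this position cannot show whether the step is particular to nitro or would also appear with another group in the same place, such as a nitrile, a carboxylic acid or an amine. Also open, from the compounds shown here alone, is whether the 4-(trifluoromethyl)phenyl to 4-nitrophenyl exchange would give a step of similar size if the rest of the structure differed from that shared by compound 1 and compound 4.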